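Two Inactive Triazole Phthalimides and a Propyl Analogue

The compounds below may be only part of what the source reports. "The series", "measured", "known", "first", "only" and "open" are said of these compounds alone.

Measured so far:
compound 1, `C#CCSc1nnc(CC)n1N1C(=O)c2ccccc2C1=O`, in a functional assay on MKN-45 cells (Homo sapiens) for cytotoxicity, read by MTT assay, with a stated time of 48 h (a higher number here means a weaker inhibitor, a lower number a stronger inhibitor), gives > 200000 nM, a limit of the assay rather than a number.
compound 2, `CCc1nnc(SCc2ccccc2)n1N1C(=O)c2ccccc2C1=O`, in this assay gives > 200000 nM, likewise a limit of the assay.

Compound 1 therefore stands only at a limit, with no number of its own. The step that the two limits leave unreadable from compound 1 to compound 2 cannot be read, since both values sit at the same limit, as the limit of > 200000 nM in this assay, at which 2 of the 2 values shown sit, records. Compound 3, `C#CCSc1nnc(CCC)n1N1C(=O)c2ccccc2C1=O`, differs from compound 1 by methyl in place of hydrogen on a saturated chain carbon, two bonds along the chain from an aromatic carbon. No measured step bears on this change: the single measured step is unreadable, and both compounds shown are limits. The expectation for this assay is therefore a step of no readable size, most likely another limit. Compound 3 is expected to give 300000 nM, between 100000 nM and 1000000 nM. The expected step is a step that the limit leaves unreadable from compound 1 to compound 3.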

Compound 3, half-maximal inhibitory concentration: > 200000 nM
Compound 3: only a limit was reported; the forecaster's own chance of this, stated with the estimate: 85%; the middle value is on the limit's open side.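

Compound 3 gives only a limit, as do compound 1 and compound 2, so the change from compound 1 to compound 3 has no readable size: the limit of > 200000 nM in this assay, at which 3 of the 3 values shown sit. The compounds shown leave open how far each lies beyond that limit, and whether any change to the shared core would give an actual number in this assay.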